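Swapping a Chlorophenylpropyl Chain for a Dichlorophenyl Ring

A few compounds are considered here, and "the series" means these few. Any claim that something is new, unique, unknown or untested is made for them only; others in the source may bear on it.

Of the compounds shown here, three with a shared core have been measured in a functional assay on CHO cells with adenosine receptor A1 (Homo sapiens) as the target, read by cAMP accumulation and immunoassay, with a stated time of 6 min, tested at 1 uM; on this read-out higher numbers stand for a weaker effect at the one concentration tested and lower numbers for a stronger effect. Compound 1 `COc1ccc(N2CCN(Cc3csc(N)c3C(=O)c3ccc(Cl)cc3)CC2)cc1` gives -15%. Compound 2 `Nc1scc(CN2CCN(c3c(F)cc(F)cc3F)CC2)c1C(=O)c1ccc(Cl)cc1` gives -56%. Compound 3 `Nc1scc(CN2CCN(CCCc3ccc(Cl)cc3)CC2)c1C(=O)c1ccc(Cl)cc1` gives -30%, the second highest of the three numbers. Compound 4 `Nc1scc(CN2CCN(c3cc(Cl)ccc3Cl)CC2)c1C(=O)c1ccc(Cl)cc1` differs from compound 3 by 2,5-dichlorophenyl in place of 3-(4-chlorophenyl)propyl on an amine nitrogen in a ring. Within the data shown here, two measured steps bear on this change: a number 26 percentage points higher from compound 2 to compound 3 (beyond the scatter) and a number 15 percentage points lower from compound 1 to compound 3 (beyond the scatter). An aryl group set directly on the ring nitrogen thus gave a much lower number in compound 2 but a somewhat higher one in compound 1. The entering ring carries chlorines, closer in kind to compound 2 than to compound 1, so a lower number is expected for compound 4, a step of about a number 15 percentage points lower from compound 3 to compound 4 (beyond the scatter). Compound 4 is therefore estimated at -45%, probably between -70% and -15%.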

Compound 4, a percentage reported as activity, at one concentration (the size of the read-out at that concentration, not a potency): -42%
The estimate for compound 4 lay 3 percentage points below the measured number; low and high end bracket the measured number.
By their numbers in this assay, from the lowest: compound 2; then compound 4; then compound 3; then compound 1.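

In this assay, the change from chain to ring gives a number 12 percentage points lower from compound 3 to compound 4 (beyond the scatter), so compound 4 joins compound 2 below the chain of compound 3, while compound 1, with its 4-methoxyphenyl ring, goes against this pattern. Among rings set directly on the ring nitrogen, the 2,5-dichlorophenyl ring falls in the middle, with a number 14 percentage points higher from compound 2 to compound 4 (beyond the scatter) and a number 27 percentage points lower from compound 1 to compound 4 (beyond the scatter) on either side. Nothing measured here explains these differences. Compound 2 and compound 4 differ in both halogen and pattern, so the two effects cannot be separated. An unsubstituted phenyl ring or a benzyl group could help to separate ring from chain.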